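A few compounds are considered here, and "the series" means these few. Any claim that something is new, unique, unknown or untested is made for them only; others in the source may bear on it.

In an assay on membranes from Sf9 cells for displacement of a labelled ligand from histamine H2 receptor (Homo sapiens), read by scintillation counting, with a stated time of 60 min (on this read-out lower numbers stand for stronger inhibition and higher numbers for weaker inhibition), the three measured compounds stand as follows.
Compound 1 `Cc1nc(N)sc1CCCN/C(N)=N/C(=O)N[C@H](C)c1ccccc1` gives 17.8 nM.
Compound 2 `CCCCCCNC(=O)/N=C(\N)NCCCc1sc(N)nc1C` gives 28.8 nM.
Compound 3 `Cc1nc(N)sc1CCCN/C(N)=N/C(=O)Nc1ccccc1` gives 3160 nM.

All three share the same core and differ only in the group on the amide-type nitrogen. Compound 3, which carries a phenyl there, has the highest number of the three and thus the weakest binding: the step of a 180-fold higher number from compound 1 to compound 3 (2.25 log units; beyond the scatter) and the step of a 110-fold higher number from compound 2 to compound 3 (2.04 log units; beyond the scatter) are both large and well beyond the scatter. Compound 1 and compound 2, with 1-phenylethyl and hexyl on that nitrogen, lie within the scatter of each other, as the step of a 1.6-fold higher number from compound 1 to compound 2 (0.21 log units; within the scatter) shows.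

Compound 4 `CCCCCNC(=O)/N=C(\N)NCCCc1sc(N)nc1C` is not yet measured. Its change from compound 3 is pentyl in place of phenyl on an amide-type nitrogen. Going by the values given here, two measured steps bear on this. The step of a 110-fold higher number from compound 2 to compound 3 (2.04 log units; beyond the scatter) exchanges hexyl for phenyl at the same place and raises the number sharply; the step of a 1.6-fold higher number from compound 1 to compound 2 (0.21 log units; within the scatter) shows that hexyl and 1-phenylethyl give similar numbers. Replacing phenyl with pentyl, a chain close to the hexyl of compound 2, is therefore expected to lower the number strongly in this assay, roughly reversing the rise seen with compound 3. The expected step is a 90-fold lower number from compound 3 to compound 4 (1.96 log units; beyond the scatter). For compound 4 the estimate is 35 nM, with a range from 12 nM to 110 nM.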

Compound 4, inhibition constant: 4.47 nM
Compound 4: the middle estimate sits 7.8-fold (0.89 log units) above what was measured; measured number outside the range, below it.
By their numbers in this assay, from the lowest: compound 4; then compounds 1 and 2 (each within the scatter of the next); then compound 3.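

In this assay, pentyl in place of phenyl on the amide-type nitrogen gives a 710-fold lower number from compound 3 to compound 4 (2.85 log units; beyond the scatter) and so takes the number lower than either earlier non-aromatic or branched group had shown. The new compound also reveals that this position can distinguish between two similar chains: pentyl in place of hexyl gives a 6.4-fold lower number from compound 2 to compound 4 (0.81 log units; beyond the scatter) and pentyl in place of 1-phenylethyl gives a 4.0-fold lower number from compound 1 to compound 4 (0.60 log units; beyond the scatter), both beyond the scatter, although hexyl and 1-phenylethyl themselves could not be told apart. Nothing available here gives a reason for these steps.

On these data alone, with only the hexyl and pentyl chains to compare, it remains open whether a shorter chain such as butyl or propyl would lower the number further or raise it again, so no best chain length can be named. Also open, as far as these compounds go, is how a benzyl group would compare with the 1-phenylethyl of compound 1 and the phenyl of compound 3 on the same nitrogen.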